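A fluorophenyl swap carried over to a dimethoxy core

This account rests on a few compounds, and the source may have more. Where it says the series, first, only, none or still open, it means among the compounds named here.

Four compounds built on a shared core are considered here. Compound 1 `C#CCOc1cccc(/C=C/C(=O)Nc2cc(C(=O)c3cc(OC)c(OC)c(OC)c3)ccc2OC)c1` carries a 3-(propargyloxy)phenyl group on a double-bonded chain carbon; in a functional assay on DU-145 cells (Homo sapiens) for cytotoxicity, read by MTT assay, with a stated time of 72 h (on this read-out higher numbers stand for weaker inhibition and lower numbers for stronger inhibition), compound 1 gives 15800 nM. Compound 2 `COc1ccc(C(=O)c2cc(OC)c(OC)c(OC)c2)cc1NC(=O)/C=C/c1ccc(F)cc1` differs from it by 4-fluorophenyl in place of 3-(propargyloxy)phenyl on a double-bonded chain carbon bound to a double-bonded chain carbon, and in this assay compound 2 gives 3900 nM, a step of a 4.1-fold lower number from compound 1 to compound 2 (0.61 log units; beyond the scatter). Compound 3 `C#CCOc1cccc(/C=C/C(=O)Nc2cc(C(=O)c3cc(OC)c(OC)c(OC)c3)cc(OC)c2OC)c1` differs from compound 1 in its core by methoxy in place of hydrogen on an aromatic carbon; in this assay compound 3 gives 13500 nM, a step of a 1.2-fold lower number from compound 1 to compound 3 (0.07 log units; within the scatter), so the two cores stand within the scatter of each other at the propargyloxyphenyl end.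

Compound 4 `COc1cc(C(=O)c2cc(OC)c(OC)c(OC)c2)cc(NC(=O)/C=C/c2ccc(F)cc2)c1OC` has not yet been measured. It differs from compound 3 by 4-fluorophenyl in place of 3-(propargyloxy)phenyl on a double-bonded chain carbon bound to a double-bonded chain carbon. The place of this change reads the same in both pairs, so it is the same change as that between compound 1 and compound 2, now made on the core of compound 3 rather than on the core of compound 1. Because the core difference amounts to a 1.2-fold lower number from compound 1 to compound 3 (0.07 log units; within the scatter), within the scatter, and because the earlier instance of the change gave a 4.1-fold lower number from compound 1 to compound 2 (0.61 log units; beyond the scatter), the step in this assay is expected to be of a similar size, a 4.1-fold lower number from compound 3 to compound 4 (0.61 log units; beyond the scatter). This expectation rests on a single measured instance of the change and is therefore tentative. Compound 4 is accordingly estimated to give 3300 nM in this assay, with a likely range from 1500 nM to 8000 nM.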

Compound 4, half-maximal inhibitory concentration: 6700 nM
Beside the measured number, compound 4's estimate is 2.0-fold (0.31 log units) below it; the measured number falls inside the stated range.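

On the core of compound 3, the same swap in this assay gives a 2.0-fold lower number from compound 3 to compound 4 (0.30 log units; within the scatter), a step that on its own does not rise above the scatter, and the two instances of the swap do not differ measurably: the same change on two cores in this assay, a 4.1-fold lower number (0.61 log units; beyond the scatter) from compound 1 to compound 2 and a 2.0-fold lower number (0.30 log units; within the scatter) from compound 3 to compound 4, 2.0-fold (0.30 log units) apart, within the scatter of two such steps. Read the other way round, the added methoxy gives a 1.7-fold higher number from compound 2 to compound 4 (0.24 log units; within the scatter), and at neither end of the molecule does it produce a step beyond the scatter, with its two readings again agreeing: the same change on two cores in this assay, a 1.2-fold lower number (0.07 log units; within the scatter) from compound 1 to compound 3 and a 1.7-fold higher number (0.24 log units; within the scatter) from compound 2 to compound 4, 2.0-fold (0.30 log units) apart, within the scatter of two such steps. These four compounds therefore fit a swap that carries from the core of compound 1 to the core of compound 3 without a measurable change in size, but they do not show that the two steps are equal, that the swap has a real effect on the core of compound 3 taken alone, or that it would carry to any further core.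

The compounds shown leave open whether the step belongs to the fluorine or to the loss of the propargyloxy group, a question that a plain phenyl or a chlorophenyl group at the same place would bear on. They also leave open how an amine or a longer chain in place of the added methoxy would read in this assay.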